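Flipping two stereocentres: expected effect on paw edema inhibition

The source may report more compounds than this note shows. Statements on the series, on what has been measured and on what is new or still open speak of the compounds shown alone.

Compound 1 `COc1cc(/C=C/C(=O)/C=C(O)/C=C/c2ccc(OC(=O)[C@H](CCSC)NC(=O)OC(C)(C)C)c(OC)c2)ccc1OC(=O)[C@H](CCSC)NC(=O)OC(C)(C)C`: 34%
Compound 2 `COc1cc(/C=C/C(=O)/C=C(O)/C=C/c2ccc(OC(=O)[C@H](C)NC(=O)OCc3ccccc3)c(OC)c2)ccc1OC(=O)[C@H](C)NC(=O)OCc1ccccc1`: 56%

Of the compounds shown here, two have been measured in a functional assay on the whole organism (strain Wistar) for inhibition, with Rattus norvegicus as the target, read by paw edema, with a stated time of 1 h, at a dose of 10 mg/kg by the intraperitoneal route; on this read-out lower numbers stand for less inhibition and higher numbers for more inhibition at the one dose given (going by the name of the read-out). Compound 1 gives 34%, the lower of the two numbers, and compound 2 gives 56%, a gap that lies beyond the usual scatter of this read-out. Among the measured compounds shown here, no single-change step links the two measured compounds, so their values are only compared, not explained.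

Compound 3 `COc1cc(/C=C/C(=O)/C=C(O)/C=C/c2ccc(OC(=O)[C@@H](CCSC)NC(=O)OC(C)(C)C)c(OC)c2)ccc1OC(=O)[C@@H](CCSC)NC(=O)OC(C)(C)C` has not yet been measured in this assay. It is built from compound 1 with this change: the two compounds have the same atoms and bonds and differ only in configuration as drawn: 2 of 5 stereo elements differ; a stereocentre at a saturated chain carbon is drawn S in compound 1 and R in compound 3; a stereocentre at a saturated chain carbon is drawn S in compound 1 and R in compound 3. Nothing is known from the measured pair about how a change of configuration alone shifts this read-out, so the expected step from compound 1 to compound 3 is none beyond the scatter, that is no change at the digits printed from compound 1 to compound 3 (within the scatter). Compound 3 is therefore estimated at 34%, within a range from 18% to 50%.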

Compound 3, a percentage reported as inhibition, in the whole organism at one dose (the size of the read-out at that dose, not a potency): 58%
For compound 3 the middle estimate is 24 percentage points below the measured one, and the stated range ends below it.
By their numbers in this assay, from the lowest: compound 1; then compounds 2 and 3 (each within the scatter of the next).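

Until now the two measured compounds differed in several places at once, so no number could be tied to configuration. In this assay, redrawing both saturated chain carbons from S to R gives a number 24 percentage points higher from compound 1 to compound 3 (beyond the scatter), which shows that the configuration at these stereocentres can by itself shift this read-out at the one dose given. The shift can be assigned to configuration, because nothing else separates the pair: the fact that compounds 1 and 3 differ only in the configuration as drawn

Both stereocentres change together, so the compounds shown do not tell whether one of them alone carries the step or whether both are needed. They also leave open whether the same change of configuration would shift the read-out for compound 2, or for an analogue whose chain ends in a carboxylic acid or an amine.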